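This account rests on a few compounds, and the source may have more. Where it says the series, first, only, none or still open, it means among the compounds named here.

Compound 1 `Nc1ncc(-c2cccc(Cl)c2)c(-c2ccccc2)n1` gives > 80% in an assay on CHO cells for displacement of a labelled ligand from adenosine receptor A1 (Homo sapiens), read by scintillation counting, with a stated time of 1 h, tested at 1 uM (on this read-out lower numbers stand for less inhibition and higher numbers for more inhibition at the one concentration tested (going by the name of the read-out)), which is a limit of the assay rather than a number. Compound 2 `COc1ccccc1-c1cnc(N)nc1-c1ccccc1` gives 20% in this assay. Compound 3 `Clc1cccc(-c2cnc(Nc3ccccc3)nc2-c2ccccc2)c1` gives 34% in this assay.

Of the two plain numbers, compound 3 stands highest, with compound 2 nearest; the remaining value is the limit (the limit of > 80% in this assay, at which 1 of the 3 values shown sits). The step from compound 3 to compound 4 `C#CCNc1ncc(-c2cccc(Cl)c2)c(-c2ccccc2)n1` is propargyl in place of phenyl on a nitrogen on an aromatic ring. Within the data shown here, the one measured step that bears on it is a number at least 46 percentage points lower from compound 1 to compound 3 (beyond the scatter), in which phenyl entered on that nitrogen; compound 4 takes that phenyl away again and puts the smaller propargyl in its place. It is therefore expected that compound 4 recovers part of that loss, an estimated rise a number 21 percentage points higher from compound 3 to compound 4 (beyond the scatter). Compound 4 is estimated at 55%, within a range from 30% to 80%.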

Compound 4, a percentage reported as inhibition, at one concentration (the size of the read-out at that concentration, not a potency): 76%
Compound 4: the middle estimate sits 21 percentage points below what was measured, and the stated range covers the measured number.
By their numbers in this assay, from the lowest: compound 2; then compound 3; then compound 4. At a limit, above all of these: compound 1.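

In this assay, the nitrogen on an aromatic ring can carry a substituent without the full loss seen with phenyl: propargyl in place of phenyl gives a number 42 percentage points higher from compound 3 to compound 4 (beyond the scatter). Propargyl in place of hydrogen gives a number at least 4 percentage points lower from compound 1 to compound 4 (that floor lies within the scatter), so no real drop can be claimed for this change. The true size of that step cannot be read because the value of compound 1 is a limit: the limit of > 80% in this assay, at which 1 of the 4 values shown sits.

On these data alone, whether a plain propyl group, without the triple bond, would hold the number as propargyl does stays open. So does how a benzyl group or a longer chain would read on this nitrogen.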